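This account rests on a few compounds, and the source may have more. Where it says the series, first, only, none or still open, it means among the compounds named here.

Measured compounds:
- compound 1 `O=C(Nc1ccccc1)Nc1ccc(Oc2ccc(-c3nccs3)cc2)cc1`: "not determined" (no result reported) in a functional assay on MDA-MB-231 cells (Homo sapiens) for inhibition, read by MTT assay and WST assay, with a stated time of 72 h, tested at 10 uM; a higher number here means more inhibition of growth at the concentration tested, a lower number less inhibition of growth
- compound 2 `Cc1ccc(NC(=O)Nc2ccc(Oc3ccc(-c4nccs4)cc3)cc2)cc1`: 22.8%
- compound 3 `O=C(Nc1ccccc1)Nc1ccc(Oc2ccc(-c3ncc[nH]3)cc2)cc1`: 11.4%

Among the two numbers available, compound 3 stands lowest. Its nearest neighbour is compound 2, whose reading is higher by a margin that lies beyond the usual scatter of this kind of measurement. Compound 1 carries no number at all in this assay, so it cannot be placed.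

The next compound, compound 4 `O=C(Nc1ccc(Oc2ccc(-c3ncc[nH]3)cc2)cc1)Nc1ccc(F)c(C(F)(F)F)c1`, keeps the whole skeleton of compound 3 and changes only the aryl group on one end of the urea: 4-fluoro-3-(trifluoromethyl)phenyl in place of phenyl on an amide-type nitrogen. Among the compounds with values here, no pair of measured compounds that differ in just one place is available here, so there is no measured step to lean on, and the expectation rests on the structural change alone together with the low starting point of compound 3.

The change from compound 3 to compound 4 is expected to raise growth inhibition, and the step of a number 33.6 percentage points higher from compound 3 to compound 4 (beyond the scatter) is estimated to lie beyond the scatter rather than within it. For compound 4 the expected reading in this assay is 45%, with a plausible range from 15% to 75%.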

Compound 4, percent growth inhibition at one concentration: 26.6%
The estimate for compound 4 lay 18.4 percentage points above the measured number; the measured number falls inside the stated range.
By their numbers in this assay, from the lowest: compound 3; then compounds 2 and 4 (each within the scatter of the next).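

In this assay, within the data shown here, putting 4-fluoro-3-(trifluoromethyl)phenyl in place of phenyl on an amide-type nitrogen gives a number 15.2 percentage points higher from compound 3 to compound 4 (beyond the scatter), the first measured step in this set between compounds that differ in one place. It shows that the reading responds to a change at this end of the urea: with the rest of the structure held constant, a plain phenyl gives way to a larger ring bearing a fluorine and a trifluoromethyl group, and growth inhibition rises by a modest amount. No measurement shown here bears on why the reading rises.

Going by these compounds, the fluorine and the trifluoromethyl group enter together, so their separate shares in the rise remain open, as does the question of whether the same exchange would have a similar effect on a different core. Also open, on these data alone, is how a phenyl carrying an amine or a carboxylic acid would read at this position, which would show whether groups of a very different kind are tolerated here.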